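A Shorter Chain on the Shared Core

A few compounds are considered here, and "the series" means these few. Any claim that something is new, unique, unknown or untested is made for them only; others in the source may bear on it.

Measured so far:
Compound 1, `COc1ccc(N(C)c2nc(C)nc3ccccc23)cc1OCCC[Se]C#N`: 815 nM
Compound 2, `COc1ccc(N(C)c2nc(C)nc3ccccc23)cc1C(=O)OCC[Se]C#N`: 1480 nM
Compound 3, `COc1ccc(N(C)c2nc(C)nc3ccccc23)cc1C(=O)OCCCC[Se]C#N`: 554 nM

All three were tested in a functional assay on MDA-MB-231 cells (Homo sapiens) for inhibition, read by MTT assay, with a stated time of 48 h; a higher number here means a weaker inhibitor, a lower number a stronger inhibitor. Compound 1 gives 815 nM, which stands second highest of the three numbers; its nearest neighbour is compound 3 with 554 nM, and its furthest is compound 2 with 1480 nM. The steps of a 1.8-fold higher number from compound 1 to compound 2 (0.26 log units; within the scatter) and a 1.5-fold lower number from compound 1 to compound 3 (0.17 log units; within the scatter) both stay within the scatter, whereas a 2.7-fold lower number from compound 2 to compound 3 (0.43 log units; beyond the scatter) is a modest step beyond it.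

Compound 4 is `COc1ccc(N(C)c2nc(C)nc3ccccc23)cc1OCC[Se]C#N`. Compared with compound 1, the change is a group of 3 heavy atoms (1 carbon, 1 nitrogen, 1 selenium; no ring) in place of a group of 4 heavy atoms (2 carbon, 1 nitrogen, 1 selenium; no ring), on a saturated chain carbon, two bonds along the chain from an oxygen on an aromatic ring. For the measured compounds named here, the only measured step that speaks to chain length is a 2.7-fold lower number from compound 2 to compound 3 (0.43 log units; beyond the scatter), where a longer chain went with a lower number; compound 4 goes the other way, with a shorter chain, though on a different linker. A small step toward a higher number is therefore expected, possibly within the scatter.

Compound 4 is estimated to give 1200 nM, with a range from 500 nM to 3000 nM, which would mean a 1.5-fold higher number from compound 1 to compound 4 (0.17 log units; within the scatter).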

Compound 4, half-maximal inhibitory concentration: 13 nM
Beside the measured number, compound 4's estimate is 92-fold (1.97 log units) above it; the whole stated range lies above it.
By their numbers in this assay, from the lowest: compound 4; then compounds 3, 1 and 2 (each within the scatter of the next, the first and the last beyond it).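

In this assay, putting the group of 3 heavy atoms in place of the group of 4 heavy atoms, on a saturated chain carbon, two bonds along the chain from an oxygen on an aromatic ring, gives a 63-fold lower number from compound 1 to compound 4 (1.80 log units; beyond the scatter), so this small change in chain length has a far larger effect than any earlier step suggested. Compound 4 also stands beyond the scatter of both other compounds, with a 43-fold lower number from compound 3 to compound 4 (1.63 log units; beyond the scatter) and a 110-fold lower number from compound 2 to compound 4 (2.06 log units; beyond the scatter), making it the strongest inhibitor of the four, and its shorter chain goes with a lower number, the opposite direction to a 2.7-fold lower number from compound 2 to compound 3 (0.43 log units; beyond the scatter), so no single rule for chain length holds across the two kinds of linker. Nothing available explains why this one change has so large an effect.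

With only two chain lengths shown on the aromatic oxygen, it remains open whether the low number belongs to this exact length or would persist with a longer chain. As far as these compounds go, it is also open whether the result depends on the selenium and the nitrile, for example whether sulfur in place of selenium would give a similar number.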